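This account rests on a few compounds, and the source may have more. Where it says the series, first, only, none or still open, it means among the compounds named here.

Measured compounds:
Compound 1 `C[C@H](Nc1nc(N)nc(N)c1C#N)c1cc2ccc(F)cn2c(=O)c1-c1ccccc1`, 1.2 h.
Compound 2 `C[C@H](Nc1nc(N)nc(N)c1C#N)c1cc(=O)n2cc(F)ccc2c1-c1cc(F)cc(F)c1`, 1 h.

Two compounds have been run in an ADME assay on the whole organism (Mus musculus, strain BALB/C) for metabolic stability, read by LC-MS, with a stated time of 24 h, at a dose of 1 mg/kg by the intravenous route; a lower number here means that the compound disappears faster, a higher number that the compound lasts longer. Compound 1 gives 1.2 h, and compound 2 gives 1 h. Compound 1 thus stands at the higher of the two numbers, but its gap to compound 2 is within the scatter, so the two half-lives cannot be told apart and no order between them is claimed. For the measured compounds named here, the two measured compounds differ in more than one place, so no measured single-point step is available from them.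

Compound 3 `Cc1c([C@H](C)Nc2nc(N)nc(N)c2C#N)c(-c2ccccc2)c(=O)n2cc(F)ccc12` has not yet been measured in this assay. It derives from compound 1 by methyl in place of hydrogen on an aromatic carbon. Going by the values given here, no measured pair shows what such a change does to the half-life, so the expectation can rest only on compound 1 and on the narrow spread between compound 1 and compound 2. The step expected here, no change at the digits printed from compound 1 to compound 3 (within the scatter), is one that lies within the scatter, with no direction beyond it. The half-life of compound 3 in this assay is therefore estimated at 1.2 h, within a range from 0.6 h to 2.4 h.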

Compound 3, half-life: 0.5 h
Estimate against measurement, compound 3: 2.4-fold (0.38 log units) above, and the stated range ends above it.
By their numbers in this assay, from the lowest: compounds 3, 2 and 1 (each within the scatter of the next, the first and the last beyond it).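

In this assay, for the compounds shown here, the single exchange of hydrogen for methyl on an aromatic carbon gives a 2.4-fold lower number from compound 1 to compound 3 (0.38 log units; beyond the scatter), a modest step but one beyond the scatter. Going by these compounds alone, it is the first step that can be read at one place, and it shows that this position, ortho to a fused ring and ortho to a large group, is not indifferent to substitution: one added heavy atom is enough to shift the half-life, and the shift is towards faster disappearance. The data offer no measured basis for explaining why the methyl has this effect on the half-life.

The compounds shown leave open whether the result belongs to methyl in particular or to any replacement of hydrogen at this position, a question that fluorine, a methoxy group, an amine or a longer chain such as ethyl at the same carbon would address. They also leave open whether the same methyl exchange would give a step of like size and direction on compound 2, with its different aromatic substituent.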